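Trifluoromethyl for Cyano on Compound 3

The compounds below may be only part of what the source reports. "The series", "measured", "known", "first", "only" and "open" are said of these compounds alone.

Compound 1 `N#Cc1ccc(/C(=C(\c2ccc(/C=C/C(=O)O)cc2)c2ccc3scnc3c2)C2CCC2)c(Cl)c1` gives 1.4 nM in a functional assay on MCF7 cells (Homo sapiens) for antiproliferative activity, read by CellTiter-Glo, with a stated time of 5 days; a lower number here means a stronger inhibitor, a higher number a weaker inhibitor. Compound 2 `O=C(O)/C=C/c1ccc(/C(=C(\c2ccc(C(F)(F)F)cc2Cl)C2CCC2)c2ccc3scnc3c2)cc1` gives 2.6 nM in this assay, and compound 3 `N#Cc1ccc(/C(=C(\c2ccc(/C=C/C(=O)O)cc2)c2ccc3nccn3c2)C2CCC2)c(Cl)c1` gives 15 nM, the highest of the three numbers; its step from compound 1 is an 11-fold higher number from compound 1 to compound 3 (1.03 log units; beyond the scatter). Compound 4 `O=C(O)/C=C/c1ccc(/C(=C(\c2ccc(C(F)(F)F)cc2Cl)C2CCC2)c2ccc3nccn3c2)cc1` differs from compound 3 in one place: trifluoromethyl in place of cyano on an aromatic carbon. Among the compounds with values here, the one step that bears on this, a 1.9-fold higher number from compound 1 to compound 2 (0.27 log units; within the scatter), lay within the scatter, so no step beyond the scatter is expected in this assay from compound 3 to compound 4. The same change made on compound 3 is estimated as a 1.7-fold higher number from compound 3 to compound 4 (0.22 log units; within the scatter). Compound 4 is therefore expected near 25 nM, with a range from 10 nM to 60 nM.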

Compound 4, half-maximal inhibitory concentration: 5.1 nM
Beside the measured number, compound 4's estimate is 4.9-fold (0.69 log units) above it; measured number below the stated range.
By their numbers in this assay, from the lowest: compounds 1, 2 and 4 (each within the scatter of the next, the first and the last beyond it); then compound 3.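

In this assay, trifluoromethyl in place of cyano at this position gives a 2.9-fold lower number from compound 3 to compound 4 (0.47 log units; beyond the scatter), so the change does not carry over unchanged from the core of compound 1 to the core of compound 3: the same change on two cores in this assay, a 1.9-fold higher number (0.27 log units; within the scatter) from compound 1 to compound 2 and a 2.9-fold lower number (0.47 log units; beyond the scatter) from compound 3 to compound 4, 5.5-fold (0.74 log units) apart, beyond the scatter of two such steps. Read from the other side, the swap of the bicyclic group costs less with trifluoromethyl than with cyano, at a 2.0-fold higher number from compound 2 to compound 4 (0.29 log units; within the scatter): the same change on two cores in this assay, an 11-fold higher number (1.03 log units; beyond the scatter) from compound 1 to compound 3 and a 2.0-fold higher number (0.29 log units; within the scatter) from compound 2 to compound 4, 5.5-fold (0.74 log units) apart, beyond the scatter of two such steps. The two places therefore do not act independently in these four compounds.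

From the compounds shown here alone, whether a methoxy or methyl group at this position would follow cyano or trifluoromethyl remains open. So does whether this dependence extends to a third core.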